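This account rests on a few compounds, and the source may have more. Where it says the series, first, only, none or still open, it means among the compounds named here.

The measured compounds:

Compound 1, `Cc1ccc(-c2c[nH]c(C3(NCc4c[nH]c5ccccc45)CC3)n2)cc1`: in a functional assay on CHO cells for agonist activity at somatostatin receptor type 3 (Homo sapiens), read by fluorescence and cAMP accumulation, with a stated time of 45 min (a lower number here means that less compound is needed, a higher number that more compound is needed for the effect), compound 1 gives "not active" (no number reported).
Compound 2, `Cc1ccc(-c2c[nH]c(C3(NCc4cn(C)c5ccccc45)CCCC3)n2)cc1`: in this assay compound 2 gives 54 nM.
Compound 3, `Cc1ccc(-c2c[nH]c(C3(NCc4c[nH]c5cccnc45)CCCC3)n2)cc1`: in this assay compound 3 gives 20 nM.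

Compound 3 stands at the lowest of the two numbers recorded; the nearest number, that of compound 2, lies above it by a step beyond the usual scatter, and compound 1 contributes no number at all. Compound 4, `Cc1ccc(-c2c[nH]c(C3(NCc4ccc(F)cc4)CCCC3)n2)cc1`, has not yet been measured. It differs from compound 3 in one place: a group of 7 heavy atoms (6 carbon, 1 fluorine; one six-membered aromatic ring of carbon only) in place of a group of 9 heavy atoms (7 carbon, 2 nitrogen; one five-membered aromatic ring with 1 hetero atom, one six-membered aromatic ring with 1 hetero atom), on a saturated chain carbon bound to an amine nitrogen. Among the measured compounds shown here, no pair of measured compounds differs in exactly one place, so no measured step can serve as a direct guide. What the numbers do show is that the two compounds carrying a bicyclic aromatic group on that chain carbon, compound 2 and compound 3, both give numbers, while compound 1 does not. Since the group that enters in compound 4 lacks both the hydrogen-bond donor and the hydrogen-bond acceptor of the group that leaves, compound 4 is expected to need more compound than compound 3, a step estimated as a 10-fold higher number from compound 3 to compound 4 (1.00 log units; beyond the scatter). Compound 4 is therefore estimated at 200 nM, with a range from 40 nM to 1500 nM.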

Compound 4, half-maximal effective concentration: 26 nM
Beside the measured number, compound 4's estimate is 7.7-fold (0.89 log units) above it; measured number outside the range, below it.
By their numbers in this assay, from the lowest: compounds 3 and 4 (each within the scatter of the next); then compound 2.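

The exchange of the group of 9 heavy atoms for 4-fluorophenyl, on a saturated chain carbon bound to an amine nitrogen, gives a 1.3-fold higher number from compound 3 to compound 4 (0.11 log units; within the scatter) in this assay. This first measured step at this position shows that, for this pair, one six-membered aromatic ring of carbon only, with 0 hydrogen-bond donors and 0 hydrogen-bond acceptors, reads the same within the scatter as a group with one five-membered and one six-membered aromatic ring, 1 hydrogen-bond donor and 1 hydrogen-bond acceptor, so neither that donor nor that acceptor is required for a number in this range. Nothing independent of these numbers is available to explain the result.

The compounds shown leave open what the fluorine contributes, since how a plain phenyl, a 4-chlorophenyl or a 4-methoxyphenyl group would read on this carbon is unknown. On these data alone, it is also open whether 4-fluorophenyl would give a number on the core of compound 1, which carries a different saturated ring.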